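Aryl ether change on a potent hydroxamate inhibitor

The source may hold more compounds than are shown below. What is called first, only, known or untested is meant among the compounds shown, and "the series" means these compounds.

Measured so far:
compound 1, `CC(C)Oc1ccc(C(C)(C)O)cc1-c1cn(C)c(=O)c2[nH]c(C(=O)NCCCCCCC(=O)NO)cc12`: 5.4 nM
compound 2, `CC(C)Oc1ccc(C(C)(C)O)cc1-c1cn(C)c(=O)c2[nH]c(C(=O)NCc3ccc(C(=O)NO)cc3)cc12`: 52 nM

Of the compounds shown here, two have been tested in an assay on isolated protein for inhibition of protein deacetylase HDAC6 (Homo sapiens), read by fluorescence; on this read-out higher numbers stand for weaker inhibition and lower numbers for stronger inhibition. Compound 1 gives 5.4 nM in this assay, the lowest of the two numbers; its nearest neighbour is compound 2, which gives 52 nM in this assay. Within the data shown here, the single measured step, a 9.6-fold higher number from compound 1 to compound 2 (0.98 log units; beyond the scatter), goes with a 4-(hydroxycarbamoyl)phenyl in place of 5-(hydroxycarbamoyl)pentyl on a saturated chain carbon bound to an amide-type nitrogen, so it concerns the hydroxamate-bearing side of the shared core.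

Compound 3, `Cn1cc(-c2cc(C(C)(C)O)ccc2Oc2ccc(F)cc2F)c2cc(C(=O)NCCCCCCC(=O)NO)[nH]c2c1=O`, keeps that side of compound 1 intact and differs at the other end: 2,4-difluorophenyl in place of isopropyl on an oxygen on an aromatic ring. Among the measured compounds shown here, no measured step touches the ether, and the one step that exists says nothing about it in either direction. For the measured compounds named here, what remains is that compound 3 carries the same side chain that gives compound 1 the lowest number so far. Compound 3 is therefore expected to come in near 7 nM, with a range from 2 nM to 25 nM. The step this estimate implies, a 1.3-fold higher number from compound 1 to compound 3 (0.11 log units; within the scatter), is expected to stay within the scatter.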

Compound 3, half-maximal inhibitory concentration: 8.7 nM
The estimate for compound 3 lay 1.2-fold (0.09 log units) below the measured number; measured number inside the range.
By their numbers in this assay, from the lowest: compounds 1 and 3 (each within the scatter of the next); then compound 2.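

At this position, on an oxygen on an aromatic ring, a much larger group leaves the number within the scatter in this assay: a 1.6-fold higher number from compound 1 to compound 3 (0.21 log units; within the scatter) goes with 2,4-difluorophenyl in place of isopropyl. The exchange replaces 3 heavy atoms and no ring with 8 heavy atoms and a six-membered aromatic ring, so this ether position accepts both a small branched group and a larger aromatic one at the level of compound 1, whereas the change on the hydroxamate-bearing side, a 9.6-fold higher number from compound 1 to compound 2 (0.98 log units; beyond the scatter), lies beyond the scatter. Nothing available explains why the number holds across this change.

The two ether groups shown do not tell whether the result extends to an unsubstituted phenyl, a 4-fluorophenyl or a 2-(dimethylamino)ethyl group on the same oxygen, so the role of the two fluorines and the limits of this position remain open. From the compounds shown here alone, it also remains open whether 2,4-difluorophenyl would leave the number unchanged when paired with the 4-(hydroxycarbamoyl)phenyl side chain of compound 2.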